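The compounds below may be only part of what the source reports. "The series", "measured", "known", "first", "only" and "open" are said of these compounds alone.

Measured so far:
compound 1, `C/N=C(\S)OC[C@H]1OC(n2cnc3c(NC4CCOC4)nc(Cl)nc32)[C@H](O)[C@@H]1O`, 71 nM in an assay on DDT1 cells (Cricetulus griseus) for binding affinity to adenosine receptor A1 (Homo sapiens), read by radioligand binding; a higher number here means a weaker inhibitor, a lower number a stronger inhibitor
compound 2, `O=C(NC1CC1)OC[C@H]1OC(n2cnc3c(NC4CCOC4)ncnc32)[C@H](O)[C@@H]1O`, 209 nM in this assay

Compound 2 stands at the highest of the two numbers; compound 1 is nearest, with a number lower by a margin beyond the usual scatter. Going by the values given here, no step between measured compounds differing in one place is available, so nothing measured bears directly on the change at hand.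

Compound 3, `CN(C)C(=O)OC[C@H]1OC(n2cnc3c(NC4CCOC4)ncnc32)[C@H](O)[C@@H]1O`, is not yet measured in this assay. It differs from compound 2 as follows: dimethylamino in place of cyclopropylamino on a carbonyl carbon. The group that leaves carries one hydrogen-bond donor; the group that enters carries none, and it is smaller by one heavy atom and has no ring.

Among the compounds with values here, with no measured step of this kind, the expectation rests on compound 2 alone: a small move upward is expected, a 1.7-fold higher number from compound 2 to compound 3 (0.22 log units; within the scatter), not clearly beyond the scatter. Compound 3 is therefore estimated at 350 nM, within 120 nM to 1000 nM.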

Compound 3, inhibition constant: 238 nM
Beside the measured number, compound 3's estimate is 1.5-fold (0.17 log units) above it; the range from low to high includes it.
By their numbers in this assay, from the lowest: compound 1; then compounds 2 and 3 (each within the scatter of the next).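

In this assay, going by these compounds alone, dimethylamino in place of cyclopropylamino on a carbonyl carbon gives a 1.1-fold higher number from compound 2 to compound 3 (0.06 log units; within the scatter), the first step that can be read at this position. Compound 2 and compound 3 cannot be told apart here, although the entering group has no ring, no hydrogen-bond donor and fewer heavy atoms, so in this pair neither the ring nor the donor is needed to keep the number within the scatter. No measurement available here accounts for this result.

A single pair cannot separate the loss of the ring from the loss of the donor; methylamino, which keeps a donor without a ring, would address this. As far as these compounds go, whether a larger group such as diethylamino or morpholino is tolerated equally at this carbonyl carbon also remains open.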